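Aryl sulfonamide changes and the next methyl step

The compounds below may be only part of what the source reports. "The series", "measured", "known", "first", "only" and "open" are said of these compounds alone.

Among the measured compounds shown here, compound 3 `Cc1cccc(S(=O)(=O)Nc2cccc(/C=C/C(=O)c3nc4ccccc4[nH]3)c2)c1` stands lowest of the three numbers so far in a functional assay on 143B cells (Homo sapiens) for antiproliferative activity, read by MTT assay, with a stated time of 48 h (on this read-out lower numbers stand for stronger inhibition and higher numbers for weaker inhibition), where compound 3 gives 791 nM. Compound 1 `Cc1cc(C)cc(C(=O)Nc2cccc(/C=C/C(=O)c3nc4ccccc4[nH]3)c2)c1` in this assay gives 4020 nM, and compound 2 `O=C(/C=C/c1cccc(NS(=O)(=O)c2ccc(Cl)cc2)c1)c1nc2ccccc2[nH]1` gives 7450 nM. The step of a 5.1-fold lower number from compound 1 to compound 3 (0.71 log units; beyond the scatter) and the step of a 9.4-fold lower number from compound 2 to compound 3 (0.97 log units; beyond the scatter) both fall beyond the scatter, while a 1.9-fold higher number from compound 1 to compound 2 (0.27 log units; within the scatter) stays within it.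

Compound 4 `Cc1ccc(S(=O)(=O)Nc2cccc(/C=C/C(=O)c3nc4ccccc4[nH]3)c2)cc1C` differs from compound 3 by methyl in place of hydrogen on an aromatic carbon; cut one bond further out, this reads 3-methylphenyl to 3,4-dimethylphenyl. For the measured compounds named here, no measured step adds a methyl to the sulfonyl aryl of compound 3. The nearest point of reference is a 9.4-fold lower number from compound 2 to compound 3 (0.97 log units; beyond the scatter), which shows that exchanging one sulfonyl aryl for another can move the number by a modest amount, and a 5.1-fold lower number from compound 1 to compound 3 (0.71 log units; beyond the scatter), which shows the same for a larger swap of the whole group on the nitrogen. A single added methyl is a smaller change than either of those, so no step beyond the scatter is expected here, in either direction. The step of a 1.1-fold higher number from compound 3 to compound 4 (0.06 log units; within the scatter) is therefore expected to stay within the scatter. Compound 4 is estimated at 900 nM, in a range of 300 nM to 3000 nM.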

Compound 4, half-maximal inhibitory concentration: 5050 nM
For compound 4 the middle estimate is 5.6-fold (0.75 log units) below the measured one, and the stated range ends below it.
By their numbers in this assay, from the lowest: compound 3; then compounds 1, 4 and 2 (each within the scatter of the next).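

In this assay the step of a 6.4-fold higher number from compound 3 to compound 4 (0.81 log units; beyond the scatter) shows that one methyl in place of hydrogen on an aromatic carbon, ortho to a methyl group and para to a large group, can by itself move the number beyond the scatter, towards weaker inhibition; until now only exchanges of a whole aryl or of the whole group on the nitrogen had been seen to do so. The step of a 1.5-fold lower number from compound 2 to compound 4 (0.17 log units; within the scatter) stays within the scatter, so 3,4-dimethylphenyl and 4-chlorophenyl on the sulfonyl sulfur are not told apart here, and among these three sulfonamides only the 3-methylphenyl of compound 3 stands apart. Nothing measured here bears on what lies behind this step.

Still open, from the compounds shown here alone, is whether 4-methylphenyl alone would behave like 3,4-dimethylphenyl or like 3-methylphenyl, and whether the step belongs to methyl itself or would also follow from methoxy, an amine or a carboxylic acid on that aromatic carbon. Also open, going by these compounds, is whether the same methyl change would move the number in the same way on the carbonyl-linked aryl of compound 1.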